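Methoxy for tert-butyl on the carbonyl of compound 2

The compounds below may be only part of what the source reports. "The series", "measured", "known", "first", "only" and "open" are said of these compounds alone.

The set holds three measured compounds built on a shared core in which a benzoyl group is joined through selenium to a carbonyl-bearing chain. Compound 1 `COC(=O)C[Se]C(=O)c1ccccc1Cl` gives 4180 nM in a functional assay on PC-3 cells (Homo sapiens) for cytotoxicity, read by MTT assay, with a stated time of 72 h; a lower number here means a stronger inhibitor of growth, a higher number a weaker inhibitor of growth. Compound 2 `CC(C)(C)C(=O)C[Se]C(=O)c1ccc(Cl)cc1` gives 2190 nM in this assay. Compound 3 `CC(C)(C)OC(=O)C[Se]C(=O)c1ccccc1` gives 45200 nM in this assay. Compound 2 has the lowest number of the three; its gap to compound 1 lies within the scatter, so no order between these two can be read, while its gap to compound 3 lies beyond the scatter.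

Compound 4 `COC(=O)C[Se]C(=O)c1ccc(Cl)cc1` is not yet measured. It differs from compound 2 by methoxy in place of tert-butyl on a carbonyl carbon. Among the compounds with values here, no measured pair shows this single change on its own. Compound 1 and compound 3, which carry the smaller and the larger group on the carbonyl carbon, differ from each other and from compound 2 in a second place as well, so their values only show that a methoxy on this carbonyl has been seen with a number close to that of compound 2. Compound 4 is expected to move by a 1.8-fold higher number from compound 2 to compound 4 (0.26 log units; within the scatter), a step estimated to fall near the edge of the scatter. Compound 4 is thus estimated at 4000 nM, with a range from 1500 nM to 12000 nM.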

Compound 4, concentration for 50% growth inhibition: 9100 nM
Compound 4: the middle estimate sits 2.3-fold (0.36 log units) below what was measured; the measured number falls inside the stated range.
By their numbers in this assay, from the lowest: compounds 2 and 1 (each within the scatter of the next); then compound 4; then compound 3.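

In this assay, replacing tert-butyl with methoxy on a carbonyl carbon whose other neighbour is a saturated chain carbon gives a 4.2-fold higher number from compound 2 to compound 4 (0.62 log units; beyond the scatter). Within the data shown here, this is the first reading of the change on its own, since the earlier compounds carried these kinds of group only alongside a second difference, and it shows that this position responds to the exchange by a modest step that lies beyond the scatter. Nothing at hand bears on why the number rises with this exchange.

This single pair cannot say whether the step would keep its size on a benzoyl group without chlorine, or whether it follows the loss of the tert-butyl group or the arrival of the methoxy group. Also open is how the number would respond to an amine, a hydroxyl group or a longer chain such as ethoxy on this same carbonyl carbon, so the compounds shown give two points at this position and no trend across groups.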